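Swapping an Oxetane Amide for a Boc-Pyrrolidine Amide

A few compounds are considered here, and "the series" means these few. Any claim that something is new, unique, unknown or untested is made for them only; others in the source may bear on it.

Of the compounds shown here, three built on one shared core have been tested in a functional assay on MIA PaCa-2 cells (Homo sapiens) for inhibition, read by MTT assay, with a stated time of 7 days; a lower number here means a stronger inhibitor, a higher number a weaker inhibitor. Compound 1 `CCN(CC)C(=O)[C@@H]1CCCN(S(=O)(=O)c2ccc(S(=O)(=O)N(CC)CC)cc2)C1` gives 6400 nM. Compound 2 `CCN(CC)S(=O)(=O)c1ccc(S(=O)(=O)N2CCC[C@@H](C(=O)NC3COC3)C2)cc1` gives 2300 nM, the second highest of the three numbers. Compound 3 `CCN(CC)S(=O)(=O)c1ccc(S(=O)(=O)N2CCC[C@@H](C(=O)N3CCN(c4nc(C)no4)CC3)C2)cc1` gives 250 nM, the lowest of the three. The compounds differ only in the group attached to the carbonyl carbon: there is a 2.8-fold lower number from compound 1 to compound 2 (0.44 log units; beyond the scatter), a 26-fold lower number from compound 1 to compound 3 (1.41 log units; beyond the scatter), and a 9.2-fold lower number from compound 2 to compound 3 (0.96 log units; beyond the scatter).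

Compound 4 `CCN(CC)S(=O)(=O)c1ccc(S(=O)(=O)N2CCC[C@@H](C(=O)N[C@H]3CCN(C(=O)OC(C)(C)C)C3)C2)cc1` awaits measurement in this assay. Relative to compound 2, (1-(tert-butoxycarbonyl)pyrrolidin-3-yl in place of oxetan-3-yl on an amide-type nitrogen). Among the measured compounds shown here, two measured steps bear on this change, namely a 26-fold lower number from compound 1 to compound 3 (1.41 log units; beyond the scatter) and a 9.2-fold lower number from compound 2 to compound 3 (0.96 log units; beyond the scatter), each of which trades a small group on that nitrogen for a larger one and lowers the number. For the measured compounds named here, because a 9.2-fold lower number from compound 2 to compound 3 (0.96 log units; beyond the scatter) was modest and the new group is not the same as the one in compound 3, a smaller gain seems likely. Compound 4 is expected to show a 2.3-fold lower number from compound 2 to compound 4 (0.36 log units; beyond the scatter). Compound 4 is estimated at 1000 nM, with a range from 250 nM to 4000 nM.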

Compound 4, half-maximal inhibitory concentration: 100 nM
For compound 4 the middle estimate is 10-fold (1.00 log units) above the measured one, and the stated range ends above it.
By their numbers in this assay, from the lowest: compound 4; then compound 3; then compound 2; then compound 1.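

Replacing oxetan-3-yl with the much larger 1-(tert-butoxycarbonyl)pyrrolidin-3-yl, while keeping the amide hydrogen, gives a 23-fold lower number from compound 2 to compound 4 (1.36 log units; beyond the scatter) and counts as a large step. On this amide-type nitrogen, then, a large gain does not depend on the oxadiazole-bearing piperazine of compound 3, and it can appear with the amide hydrogen still in place, as compound 2 and compound 4 both have it. Nothing measured here explains why the number falls so far.

The compounds shown leave open whether the gain comes from the pyrrolidine ring or from the tert-butoxycarbonyl group on it. A pyrrolidin-3-yl with a free amine, or with an acetyl group in place of tert-butoxycarbonyl, would help to separate the two, and the opposite configuration at the defined stereocentre would show whether that centre matters.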